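Nitro to cyano on the urea aryl group

The source may hold more compounds than are shown below. What is called first, only, known or untested is meant among the compounds shown, and "the series" means these compounds.

Compound 1 `N#Cc1cccc([C@]23CCC(N(CCN4CC[C@@H](O)C4)C(=O)Nc4cccc([N+](=O)[O-])c4)CC2C3)c1` gives 60 nM in a functional assay for antagonist activity at melanin-concentrating hormone receptor 1 (Homo sapiens); on this read-out higher numbers stand for weaker inhibition and lower numbers for stronger inhibition. Among the measured compounds shown here, compound 2 `CC(C)N(CCN(C(=O)Nc1cccc([N+](=O)[O-])c1)C1CC[C@]2(c3cccc(C#N)c3)CC2C1)C(C)C` gives 2.7 nM in this assay, the lowest of the two numbers so far; the difference is a 22-fold lower number from compound 1 to compound 2 (1.35 log units; beyond the scatter). Compound 3 `CC(C)N(CCN(C(=O)Nc1cccc(C#N)c1)C1CC[C@]2(c3cccc(C#N)c3)CC2C1)C(C)C` is not yet measured. For the measured compounds named here, it differs from compound 2 by cyano in place of nitro on an aromatic carbon, on the aryl group of the urea, away from the amine side chain that the one measured step changes. Going by the values given here, no measured step therefore bears on this change; the step from compound 1 to compound 2 altered a different part of the molecule, and nothing shows what replacing nitro with cyano on this ring does. In the absence of a bearing step, the expectation for this assay is a step of a 1.3-fold higher number from compound 2 to compound 3 (0.11 log units; within the scatter) from compound 2 to compound 3, within the scatter. Compound 3 is estimated at 3.5 nM, with a range from 1 nM to 12 nM.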

Compound 3, inhibition constant: 7.6 nM
For compound 3 the middle estimate is 2.2-fold (0.34 log units) below the measured one; the range from low to high includes it.
By their numbers in this assay, from the lowest: compound 2; then compound 3; then compound 1.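

The urea aryl group now has its first reading: in this assay, the change from 3-nitrophenyl to 3-cyanophenyl gives a 2.8-fold higher number from compound 2 to compound 3 (0.45 log units; beyond the scatter), beyond the scatter but modest. This step is smaller than a 22-fold lower number from compound 1 to compound 2 (1.35 log units; beyond the scatter) on the amine side chain, and with nitro gone, compound 3 still gives 7.6 nM, so nitro is not essential for inhibition in the diisopropylamino series. Nothing measured on these compounds accounts for the step.

As far as these compounds go, it remains open whether the same change gives a step of similar size with the 3-hydroxypyrrolidin-1-yl side chain of compound 1. Also open, from the compounds shown here alone, is how a trifluoromethyl group or a chlorine atom on the same aromatic carbon would compare with nitro and cyano.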